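A few compounds are considered here, and "the series" means these few. Any claim that something is new, unique, unknown or untested is made for them only; others in the source may bear on it.

Three compounds have been measured so far in a functional assay on HepG2 cells (Homo sapiens) for antiproliferative activity, read by MTT assay, with a stated time of 48 h (a lower number here means a stronger inhibitor, a higher number a weaker inhibitor), and give these values:

Compound 1 `COc1ccc(/C=C/c2cc(OC)cc(OC)c2/C=C/C(=O)c2ccc(Cl)c(Cl)c2)cc1` at 10.8 ug/mL
Compound 2 `COc1ccc(/C=C/c2cc(OC)cc(OC)c2/C=C/C(=O)c2cccc(OC)c2)cc1` at 11.6 ug/mL
Compound 3 `COc1ccc(/C=C/c2cc(OC)cc(OC)c2/C=C/C(=O)c2ccc(C(F)(F)F)cc2)cc1` at 18.7 ug/mL

All three share one core and differ only in the group on the carbonyl carbon. Compound 3 stands within the scatter of both others, as the steps (a 1.6-fold higher number from compound 2 to compound 3 (0.21 log units; within the scatter)) and (a 1.7-fold higher number from compound 1 to compound 3 (0.24 log units; within the scatter)) show, so its place among the numbers carries little weight.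

Compound 4 `COc1ccc(/C=C/c2cc(OC)cc(OC)c2/C=C/C(=O)c2ccc(Cl)cc2)cc1` has not yet been measured. It keeps the core of compound 3 and has chloro in place of trifluoromethyl on an aromatic carbon, para to a large group (chloro in place of trifluoromethyl on an aromatic carbon). The best guide is compound 1, the only measured relative that also carries chloro on this ring, which gives 10.8 ug/mL in its 3,4-dichlorophenyl form. The remaining swap of this group (a 1.1-fold higher number from compound 1 to compound 2 (0.03 log units; within the scatter)) also stayed small. No change beyond the scatter is therefore expected in this assay, only perhaps a slight drift towards the number of compound 1. The expected step, a 1.4-fold lower number from compound 3 to compound 4 (0.16 log units; within the scatter) in size, would stay inside the usual scatter. For compound 4 the estimated value is 13 ug/mL, with an expected range of 7 ug/mL to 24 ug/mL.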

Compound 4, half-maximal inhibitory concentration: 13.6 ug/mL
Beside the measured number, compound 4's estimate is 1.0-fold (0.02 log units) below it; low and high end bracket the measured number.
By their numbers in this assay, from the lowest: compounds 1, 2, 4 and 3 (each within the scatter of the next).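

In this assay, the place on an aromatic carbon, para to a large group, now has a direct one-place swap: chloro in place of trifluoromethyl gives a 1.4-fold lower number from compound 3 to compound 4 (0.14 log units; within the scatter), so a group of four heavy atoms gives way to a single atom without the number leaving the usual scatter. The ring can now also be compared in two other ways: hydrogen in place of chloro gives a 1.3-fold higher number from compound 1 to compound 4 (0.10 log units; within the scatter), and 4-chlorophenyl in place of 3-methoxyphenyl on the carbonyl carbon gives a 1.2-fold higher number from compound 2 to compound 4 (0.07 log units; within the scatter), so every one-place change among these four compounds stays within the scatter. Nothing measured here explains why these numbers lie so close together.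

The compounds shown cannot tell whether an amine or a carboxylic acid at this same place would also stay within the scatter, since every group seen there so far has no hydrogen-bond donors, no hydrogen-bond acceptors and no net charge. They also say nothing about the shared core, for instance what would follow if hydroxyl replaced one of its methoxy groups.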